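The source may report more compounds than this note shows. Statements on the series, on what has been measured and on what is new or still open speak of the compounds shown alone.

Compound 1 `Nc1ncnn1/C(S)=N/C1CCCCC1`: in an ADME assay on MT4 cells (Homo sapiens) for cytotoxicity, read by MTT assay, with a stated time of 96 h (a lower number here means that less compound is tolerated, a higher number that more compound is tolerated), compound 1 gives > 100000 nM, a limit of the assay rather than a number.
Compound 2 `Nc1ncnn1/C(S)=N/Cc1ccccc1`: in this assay compound 2 gives 7400 nM.
Compound 3 `COc1ccc(NC(=S)Nc2nc[nH]n2)cc1`: in this assay compound 3 gives > 100000 nM, again a limit of the assay.

Compound 3 therefore stands at the limit of > 100000 nM in this assay, at which 2 of the 3 values shown sit, which means only a lower bound is known for it; the cells tolerated it up to the highest concentration tested. Compound 4 `S=C(Nc1ccc(Br)cc1)Nc1nc[nH]n1` differs from it in one place: bromo in place of methoxy on an aromatic carbon. Within the data shown here, no measured pair shows this change, so no size of step can be read from the data. The expectation is that compound 4 will behave much like compound 3 in this assay, with no step beyond the usual scatter, and will most likely again reach the limit. Compound 4 is expected to give 100000 nM, within 30000 nM to 300000 nM. The step of a number no higher from compound 3 to compound 4 (the limit leaves the size open) is thus expected to stay within the scatter.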

Compound 4, half-maximal cytotoxic concentration: > 100000 nM
Compound 4: a limit, no number; the forecaster's own chance of this, stated with the estimate: 65%; the middle value sits exactly at the limit.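

Among these compounds, compound 3 and compound 4 each give only a limit of the assay, not a number, and no step between them can be read. Going by these compounds, whether bromo in place of methoxy on an aromatic carbon changes the tolerated concentration in this assay stays open.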